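Compound 4 against the one number in the series

The source may hold more compounds than are shown below. What is called first, only, known or untested is meant among the compounds shown, and "the series" means these compounds.

Going by the values given here, in a functional assay on U-373MG ATCC cells for inhibition, with U373 MG (Homo sapiens) as the target, read by MTT assay, with a stated time of 7 days (on this read-out lower numbers stand for stronger inhibition of growth and higher numbers for weaker inhibition of growth), compound 1 `C[Si](C)(C)CCOCn1nnc2c(C(N)=O)ncn2c1=O` gives 25300 nM, the only number that is not a limit. Compound 2 `COc1ccc(Cn2nnc3c(C(N)=O)ncn3c2=O)cc1OC` reads > 50000 nM, which is a limit. Compound 3 `COc1cc(Cn2nnc3c(C(N)=O)ncn3c2=O)cc(OC)c1OC` reads > 50000 nM, also a limit. Between these two stands a step that the two limits leave unreadable from compound 2 to compound 3, so it sets no size. The nearest guide is the limit of > 50000 nM in this assay, at which 2 of the 3 values shown sit, where both ring-bearing compounds sit. Compound 4 `NC(=O)c1ncn2c(=O)n(Cc3ccsc3)nnc12` differs from compound 1 by a group of 5 heavy atoms (4 carbon, 1 sulfur; one five-membered aromatic ring with 1 hetero atom) in place of a group of 7 heavy atoms (5 carbon, 1 oxygen, 1 silicon; no ring), on a saturated chain carbon bound to an aromatic nitrogen. Weaker growth inhibition is therefore expected, though no measured step fixes how much. The expected change is a 2.4-fold higher number from compound 1 to compound 4 (0.38 log units; beyond the scatter), and it may reach the limit. For compound 4 the estimated value is 60000 nM, with an expected range of 25000 nM to 150000 nM.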

Compound 4, concentration for 50% growth inhibition: > 50000 nM
Compound 4 was reported as a limit (the forecaster's own chance of this, stated with the estimate: 60%); the middle value lies beyond the limit too.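

In this assay, thiophen-3-yl on the saturated chain carbon bound to an aromatic nitrogen gives an at least 1.9-fold higher number from compound 1 to compound 4 (0.29 log units; that floor lies within the scatter). That floor does not by itself establish a real loss, and the size of the step stays unreadable beyond it. Of the compounds shown, only compound 1, with no ring in this group, gives a number, while compound 2, compound 3 and compound 4, each with an aromatic ring in it, stop at a limit: the limit of > 50000 nM in this assay, at which 3 of the 4 values shown sit.

As far as these compounds go, how far compound 4 lies past the limit remains open. So does whether a plain butyl chain or an amine-bearing chain, with neither ring nor silicon, would keep a readable number.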